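Adding Chlorine to a Compound Sitting at the Assay Limit

This account rests on a few compounds, and the source may have more. Where it says the series, first, only, none or still open, it means among the compounds named here.

compound 1, `Cc1cc(Nc2ccc(Cl)cc2Cl)nc(N)n1`: > 180000 nM
compound 2, `Cc1cc(Nc2ccccc2C)nc(N)n1`: > 180000 nM

In an assay on cells for inhibition of S-adenosylmethionine decarboxylase proenzyme (Homo sapiens), read by mass spectrometry, at pH 7.2 (a lower number here means a stronger inhibitor, a higher number a weaker inhibitor), compound 1 gives only a limit, > 180000 nM. Compound 2 likewise gives only a limit, > 180000 nM. Compound 2 thus stands at the limit of > 180000 nM in this assay, at which 2 of the 2 values shown sit, with no number to place it against anything. Compound 3, `Cc1cc(Nc2ccc(Cl)cc2C)nc(N)n1`, differs from compound 2 by chloro in place of hydrogen on an aromatic carbon. Among the compounds with values here, no step between measured compounds is known, and the two limits give no sign that this change would yield a measurable number. Compound 3 is expected at 200000 nM (range 60000 nM to 700000 nM). The expected change, a step that the limit leaves unreadable from compound 2 to compound 3, is none beyond the usual scatter.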

Compound 3, half-maximal inhibitory concentration: > 180000 nM
Compound 3 gave a limit, no number; the forecaster's own chance of this, stated with the estimate: 85%; the middle value is on the limit's open side.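

In this assay no step can be read among compound 1, compound 2 and compound 3, because each gives only a limit: the limit of > 180000 nM in this assay, at which 3 of the 3 values shown sit.

The compounds shown leave open how far chloro in place of hydrogen on an aromatic carbon shifts inhibition, if at all.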